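The compounds below may be only part of what the source reports. "The series", "measured", "known", "first", "only" and "open" are said of these compounds alone.

In a functional assay on HepG2 cells (Homo sapiens) for antiproliferative activity, read by spectrophotometry, with a stated time of 2 days (a higher number here means a weaker inhibitor of growth, a lower number a stronger inhibitor of growth), compound 1 (`CN(c1cccc2c1CN(c1nc(Nc3ccc(C(F)(F)F)cc3)ncc1C(F)(F)F)C2)S(C)(=O)=O`) reaches only a limit, > 30000 nM. Compound 2 (`Cc1cc(C)cc(Nc2ncc(C(F)(F)F)c(N3Cc4cccc(N(C)S(C)(=O)=O)c4C3)n2)c1`) also reaches only a limit, > 30000 nM, so its standing has no number behind it. Within the data shown here, the only measured step is a step that the two limits leave unreadable from compound 1 to compound 2, and the series so far shows (the limit of > 30000 nM in this assay, at which 2 of the 2 values shown sit). Compound 3 (`CN(c1cccc2c1CN(c1nc(Nc3ccc(Cl)c(C(F)(F)F)c3)ncc1C(F)(F)F)C2)S(C)(=O)=O`) has 4-chloro-3-(trifluoromethyl)phenyl in place of 3,5-dimethylphenyl on a nitrogen on an aromatic ring. With no readable step as a guide, no change beyond the scatter is expected in either direction, and the estimated step is a number no higher from compound 2 to compound 3 (the limit leaves the size open). The estimate for compound 3 is 30000 nM, with the expected range running from 10000 nM to 60000 nM.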

Compound 3, concentration for 50% growth inhibition: 16000 nM
For compound 3 the middle estimate is 1.9-fold (0.27 log units) above the measured one, within the range that was stated.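

Among these compounds, with 4-chloro-3-(trifluoromethyl)phenyl on the nitrogen, compound 3 gives the first actual number in this assay, 16000 nM, so this position can yield a readable value. The change reads as an at least 1.8-fold lower number from compound 2 to compound 3 (0.27 log units; that floor lies within the scatter), and as an at least 1.8-fold lower number from compound 1 to compound 3 (0.27 log units; that floor lies within the scatter). Both steps are only floors, as each starts from a limit and not a number: the limit of > 30000 nM in this assay, at which 2 of the 3 values shown sit.

From the compounds shown here alone, it remains open how far the true steps extend and whether the chlorine alone would give the same reading. Going by these compounds, how an amine or a carboxylic acid on this phenyl ring would read also stays open.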